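A few compounds are considered here, and "the series" means these few. Any claim that something is new, unique, unknown or untested is made for them only; others in the source may bear on it.

Among the compounds with values here, in an assay on membranes from brain for binding affinity to Lysophosphatidylserine lipase ABHD12 (Mus musculus), read by fluorescence, with a stated time of 20 min (a higher number here means a weaker inhibitor, a lower number a stronger inhibitor), compound 2 `FC(F)(F)Oc1ccc(Oc2ccnc(N3CCC(NC(=S)Nc4cccnc4)CC3)c2)cc1` gives 410 nM, the highest of the three numbers measured so far. Compound 1 `FC(F)(F)Oc1ccccc1Oc1ccnc(N2CCC(NC(=S)Nc3cccnc3)CC2)c1Cl` gives 96 nM, and compound 3 `Cc1c(Oc2ccc(OC(F)(F)F)cc2)ccnc1N1CCC(NC(=S)Nc2cccnc2)CC1` gives 26 nM. Within the data shown here, the only single-point step between measured compounds is a 16-fold lower number from compound 2 to compound 3 (1.20 log units; beyond the scatter), a methyl in place of hydrogen on an aromatic carbon. Compound 4 `COc1ccc(Oc2ccnc(N3CCC(NC(=S)Nc4cccnc4)CC3)c2)cc1` differs from compound 2 in a different place: methyl in place of trifluoromethyl on an oxygen on an aromatic ring, so that trifluoromethoxy becomes methoxy. Among the measured compounds shown here, no measured step touches the group on the oxygen, so the change from compound 2 to compound 3 offers no direct guide, and no step beyond the scatter is expected. The estimated step is a 1.2-fold higher number from compound 2 to compound 4 (0.09 log units; within the scatter). Compound 4 is thus expected to give 500 nM in this assay, within a range of 150 nM to 1600 nM.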

Compound 4, half-maximal inhibitory concentration: 2900 nM
Compound 4: the middle estimate sits 5.8-fold (0.76 log units) below what was measured; measured number above the stated range.
By their numbers in this assay, from the lowest: compound 3; then compound 1; then compound 2; then compound 4.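

In this assay, the group on the oxygen proves to matter: going from trifluoromethoxy to methoxy gives a 7.1-fold higher number from compound 2 to compound 4 (0.85 log units; beyond the scatter). Within the data shown here, this is the first measured change at this place, and it shows that trifluoromethyl and methyl are not interchangeable here, at least on the core of compound 2. Nothing available explains this difference. From the compounds shown here alone, whether the same change would cost as much on the core of compound 3 remains open. So does how an ethoxy, a difluoromethoxy or a chlorine at this place would compare.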